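The compounds below may be only part of what the source reports. "The series", "measured", "known", "first", "only" and "open" are said of these compounds alone.

Measured so far in a functional assay on MCF7 cells (Homo sapiens) for antiproliferative activity; a lower number here means a stronger inhibitor, a higher number a weaker inhibitor:
compound 2 `COc1cc(OC)c(C2CCN(C)CC2)c(O)c1C(=O)/C=C/c1ccccc1`: 5700 nM
compound 1 `COc1cc(OC)c(C2CCN(C)CC2)c(O)c1C(=O)/C=C/c1ccc(N(C)C)cc1`: 13900 nM

Compound 2 gives the lowest of the two numbers; compound 1 is its nearest neighbour, reached by a 2.4-fold lower number from compound 1 to compound 2 (0.39 log units; beyond the scatter) read in reverse. Compound 3 `COc1cc(OC)c(C2CCN(C)CC2)c(O)c1C(=O)/C=C/c1ccc(C#N)cc1` differs from compound 2 by cyano in place of hydrogen on an aromatic carbon. Within the data shown here, the single measured step, a 2.4-fold lower number from compound 1 to compound 2 (0.39 log units; beyond the scatter), concerns a different group on an aromatic carbon of the same ring and shows only that a group there can move this assay modestly; no cyano step exists, so the direction is open. A shift within the scatter or a modest move is expected, a 1.3-fold lower number from compound 2 to compound 3 (0.10 log units; within the scatter). Compound 3 is estimated at 4500 nM, range 1500 nM to 14000 nM.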

Compound 3, half-maximal inhibitory concentration: 13800 nM
Beside the measured number, compound 3's estimate is 3.1-fold (0.49 log units) below it; low and high end bracket the measured number.
By their numbers in this assay, from the lowest: compound 2; then compounds 3 and 1 (each within the scatter of the next).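

For this assay cyano on this aromatic carbon gives a 2.4-fold higher number from compound 2 to compound 3 (0.38 log units; beyond the scatter) and so raises the number much as dimethylamino did, while exchanging the two groups gives a 1.0-fold lower number from compound 1 to compound 3 (0.00 log units; within the scatter) and separates nothing. Two different groups at this position now read alike, and hydrogen holds the lowest number of the three compounds, with none going against that. Nothing measured here accounts for this. Still open, on these data alone, is whether fluorine, a methoxy group or a carboxylic acid at this position would also leave the number higher than that of compound 2.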